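Fluoro to nitro: what compound 3 may show

The compounds below may be only part of what the source reports. "The series", "measured", "known", "first", "only" and "open" are said of these compounds alone.

Compound 1 `CCCN1CCN(c2ccc(S(=O)(=O)Oc3ccccc3OC)cc2)C1=O`: > 100000 nM (a limit, not a number)
Compound 2 `CCCN1CCN(c2ccc(S(=O)(=O)Oc3cccc(F)c3)cc2)C1=O`: 18000 nM

For the measured compounds named here, in a functional assay on HT-29 cells (Homo sapiens) for antiproliferative activity, read by sulforhodamine B assay, with a stated time of 48 h (on this read-out higher numbers stand for weaker inhibition and lower numbers for stronger inhibition), compound 2 gives 18000 nM, the only actual number so far. Compound 1 reaches only a limit, > 100000 nM.

Compound 3 `CCCN1CCN(c2ccc(S(=O)(=O)Oc3cccc([N+](=O)[O-])c3)cc2)C1=O` changes one group of compound 2: nitro in place of fluoro on an aromatic carbon. In words, this is nitro in place of fluoro on an aromatic carbon, or 3-fluorophenyl to 3-nitrophenyl.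

Just one measured step bears on this: an at least 5.5-fold lower number from compound 1 to compound 2 (0.74 log units; beyond the scatter). Going by the values given here, it shows that the group on that oxygen can shift the read-out, but it starts from the limit of > 100000 nM in this assay, at which 1 of the 2 values shown sits, and no nitro compound has been measured. Size and direction therefore stay open in this assay. The expected change is small, within the usual scatter: a 1.2-fold lower number from compound 2 to compound 3 (0.08 log units; within the scatter). For compound 3 the estimate is 15000 nM, with an expected range from 4000 nM to 60000 nM.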

Compound 3, half-maximal inhibitory concentration: > 100000 nM
Compound 3: a limit, no number; the forecaster's own chance of this, stated with the estimate: 15%; at least 6.6-fold (0.82 log units) between middle value and limit.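

Holding the position fixed and changing only the group, nitro in place of fluoro on an aromatic carbon, gives in this assay an at least 5.5-fold higher number from compound 2 to compound 3 (0.74 log units; beyond the scatter). The earlier step changed both the group and where it sat on the phenyl ring, whereas this one shows that the group alone can weaken the inhibition, and of the compounds shown only compound 2 gives an actual number. The true size of this step stays unknown and the step between the other two compounds cannot be read, because their values are limits and not numbers: the limit of > 100000 nM in this assay, at which 2 of the 3 values shown sit.

From the compounds shown here alone, whether chloro, methyl or an amine at this position would match compound 2 or improve on it remains open. So does the read-out of a plain phenyl with only hydrogen there, which would show whether fluoro itself helps.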